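Anilino in place of hydroxy on compound 2

The source may report more compounds than this note shows. Statements on the series, on what has been measured and on what is new or still open speak of the compounds shown alone.

In a functional assay on KB cells (Homo sapiens) for inhibition, read by MTT assay, with a stated time of 24 h, tested at 1 ug/mL (a lower number here means less inhibition of growth, a higher number more inhibition of growth at the concentration tested), compound 1 (`CC(=O)SCCC(CCCCC(=O)O)SC(C)=O`) gives 12.4% and compound 2 (`O=C(O)CCCCC(CCSC(=O)c1ccccc1)SC(=O)c1ccccc1`) gives 0.68%, a number beyond the scatter below compound 1 and within the scatter of compound 3 (`O=C(CCCCC1CCSS1)Nc1cccc2ccccc12`). Compound 4 (`O=C(CCCCC(CCSC(=O)c1ccccc1)SC(=O)c1ccccc1)Nc1ccccc1`) differs from compound 2 in one place: anilino in place of hydroxy on a carbonyl carbon, with anilino in place of hydroxy on a carbonyl carbon. Going by the values given here, no measured pair shows this change directly. Compound 3 also lacks the carboxy group and gives 8.37% in this assay, which stays within the scatter of compound 2. A small upward move and no step beyond the scatter is therefore expected, an estimated a number 5.3 percentage points higher from compound 2 to compound 4 (within the scatter) in this assay. For compound 4 the estimate is 6%, with an expected range of 0% to 17%.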

Compound 4, percent growth inhibition at one concentration: "not active" (no number reported)
Nothing numeric was reported for compound 4, so the estimate cannot be set against anything.
By their numbers in this assay, from the lowest: compounds 2, 3 and 1 (each within the scatter of the next, the first and the last beyond it).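

In this assay, going by these compounds alone, compound 4 is reported as "not active" (no number reported) and so no step from compound 2 can be read. The compounds shown leave open what anilino in place of hydroxy does to growth inhibition, and nothing measured here offers an explanation.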